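The source may hold more compounds than are shown below. What is called first, only, known or untested is meant among the compounds shown, and "the series" means these compounds.

Working notes on the series. The shared core of compound 3 `CC/N=C(\S)NCCCCCn1nc(-c2ccccc2)ccc1=O` carries a side chain ending in the sulfur-bearing group; in a functional assay on the whole organism with Rattus norvegicus as the target, at a dose of 100 mg/kg (on this read-out lower numbers stand for less inhibition and higher numbers for more inhibition at the one dose given (going by the name of the read-out)), compound 3 gives 66.4%. Within the three numbers known, compound 3 stands second highest: its nearest neighbour is compound 2 `C/N=C(\S)NCCCCCn1nc(-c2ccccc2)ccc1=O`, which gives 68.9%, and the two lie within the scatter, the step of a number 2.5 percentage points lower from compound 2 to compound 3 (within the scatter). Furthest off is compound 1 `C/N=C(/NC#N)NCCCn1nc(-c2ccccc2)ccc1=O`, which gives 40.5%.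

Compound 4 `CC/N=C(/NC#N)NCCCn1nc(-c2ccccc2)ccc1=O` differs from compound 3 by a group of 8 heavy atoms (4 carbon, 4 nitrogen; no ring) in place of a group of 8 heavy atoms (5 carbon, 2 nitrogen, 1 sulfur; no ring), on a saturated chain carbon, three bonds along the chain from an aromatic nitrogen. Going by the values given here, two measured steps bear on this exchange, both in the opposite direction. The step of a number 25.9 percentage points higher from compound 1 to compound 3 (beyond the scatter) is the exact reverse of the change now proposed apart from the ethyl for methyl, and the step of a number 28.4 percentage points higher from compound 1 to compound 2 (beyond the scatter) is its close analogue; these two agree on a modest gain for the sulfur-bearing side chain. The ethyl for methyl part, as seen in a number 2.5 percentage points lower from compound 2 to compound 3 (within the scatter), contributes nothing beyond the scatter.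

Going back to the nitrile-bearing chain should therefore undo the gain, and a modest drop is expected, a number 24.4 percentage points lower from compound 3 to compound 4 (beyond the scatter). Compound 4 is estimated to give 42%, with a range of 25% to 59%, because compound 1 with the same chain gives 40.5%.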

Compound 4, a percentage reported as inhibition, in the whole organism at one dose (the size of the read-out at that dose, not a potency): 62.9%
Estimate against measurement, compound 4: 20.9 percentage points below; the measured number lies above the stated range.
By their numbers in this assay, from the lowest: compound 1; then compounds 4, 3 and 2 (each within the scatter of the next).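

In this assay, the exchange of the sulfur-bearing group for the nitrile-bearing group does not by itself bring a loss when the end of the group is ethyl, as a number 3.5 percentage points lower from compound 3 to compound 4 (within the scatter) and a number 6 percentage points lower from compound 2 to compound 4 (within the scatter) both show, so the three compounds stand level with one another. The low number of compound 1 therefore does not follow from the nitrile-bearing group alone, and on that core methyl in place of hydrogen on a saturated chain carbon bound to a double-bonded nitrogen counts, giving a number 22.4 percentage points higher from compound 1 to compound 4 (beyond the scatter). This change cannot be carried from one core to the other, and the earlier step on the sulfur-bearing core gave no hint of its size on the nitrile-bearing core: the same change on two cores in this assay, a number 2.5 percentage points lower (within the scatter) from compound 2 to compound 3 and a number 22.4 percentage points higher (beyond the scatter) from compound 1 to compound 4, 24.9 percentage points apart, beyond the scatter of two such steps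

The compounds shown leave open whether a propyl or a cyclopropyl at this end of the nitrile-bearing group would hold the number of compound 4 or lose it. They also leave open whether a urea carbonyl in place of the sulfur-bearing or nitrile-bearing part would behave like either, and the single dose gives the size of the read-out, not a potency.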